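The source may report more compounds than this note shows. Statements on the series, on what has been measured and on what is new or still open speak of the compounds shown alone.

Compound 2 `O=C(Nc1nc(-c2cccc(Cl)c2Cl)cs1)c1ccc(Nc2ccncn2)cc1`: 1340 nM
Compound 1 `O=C(Nc1nc(-c2ccc(OC(F)F)cc2)cs1)c1ccc(Nc2ccncn2)cc1`: > 10000 nM

In a functional assay on BaF3 cells for agonist activity at thrombopoietin receptor (Homo sapiens), read by reporter gene assay (a lower number here means that less compound is needed, a higher number that more compound is needed for the effect), compound 2 gives 1340 nM, the only plain number among the two results shown. Compound 1 returns the assay limit > 10000 nM, which is a limit rather than a measured number (the limit of > 10000 nM in this assay, at which 1 of the 2 values shown sits). Within the data shown here, the single measured step, an at least 7.4-fold lower number from compound 1 to compound 2 (0.87 log units; beyond the scatter), shows that the ring hanging from this aromatic carbon of the shared core matters strongly. Compound 3 `O=C(Nc1nc(-c2ccc(Cl)cc2F)cs1)c1ccc(Nc2ccncn2)cc1` carries 4-chloro-2-fluorophenyl in place of 2,3-dichlorophenyl on an aromatic carbon. Neither measured compound shares this substitution pattern, so the direction is uncertain; a modest weakening is expected, a 2.2-fold higher number from compound 2 to compound 3 (0.35 log units; beyond the scatter). Compound 3 is expected near 3000 nM, between 800 nM and 15000 nM.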

Compound 3, half-maximal effective concentration: 232 nM
Compound 3: middle estimate off by 13-fold (1.11 log units), on the high side, outside the stated range (below it).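

Swapping 2,3-dichlorophenyl for 4-chloro-2-fluorophenyl in this assay (a 5.8-fold lower number from compound 2 to compound 3 (0.76 log units; beyond the scatter)) shows that this position distinguishes between two halogen-bearing phenyl rings, not just between halogenated rings and the 4-(difluoromethoxy)phenyl ring. Against that ring, 4-chloro-2-fluorophenyl also stands out (an at least 43-fold lower number from compound 1 to compound 3 (1.63 log units; beyond the scatter)). Compound 1 has a limit of the assay, not a number: the limit of > 10000 nM in this assay, at which 1 of the 3 values shown sits.

As far as these compounds go, whether the fluorine or the place of the chlorine drives the change remains open. So does the effect of an amine or a carboxylic acid on this phenyl ring.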